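A Methoxyphenyl Swap in a Cytotoxicity Series

The source may hold more compounds than are shown below. What is called first, only, known or untested is meant among the compounds shown, and "the series" means these compounds.

In an ADME assay on HEK293 cells (Homo sapiens) for cytotoxicity, read by MTT assay, with a stated time of 48 h (on this read-out higher numbers stand for weaker inhibition and lower numbers for stronger inhibition), compound 1 `Cc1nc(-c2ccc(Cl)cc2)sc1C(=O)CSc1nc(-c2cccc(Cl)c2)c(C#N)c(=O)[nH]1` gives 30100 nM and compound 2 `Cc1nc(-c2ccc(Cl)cc2)sc1C(=O)CSc1nc(-c2ccc(Cl)cc2)c(C#N)c(=O)[nH]1` gives 75100 nM, the higher of the two numbers and so the weaker inhibition. Compound 3 `COc1cccc(-c2nc(SCC(=O)c3sc(-c4ccc(Cl)cc4)nc3C)[nH]c(=O)c2C#N)c1` differs from compound 2 in one group, on an aromatic carbon ortho to a cyano group: 3-methoxyphenyl in place of 4-chlorophenyl on an aromatic carbon. Going by the values given here, only one measured step bears on this change. With 4-chlorophenyl in place of 3-chlorophenyl, the step was modest: a 2.5-fold higher number from compound 1 to compound 2 (0.40 log units; beyond the scatter). The 3-methoxyphenyl of compound 3 shares its numbered pattern with the 3-chlorophenyl of compound 1, which gives 30100 nM. Among the compounds with values here, no measured step shows how methoxy compares with chlorine, so the expectation is loose. A modest move to a lower number in this assay is expected: a 2.1-fold lower number from compound 2 to compound 3 (0.32 log units; beyond the scatter). The estimate for compound 3 is 36000 nM, with an expected range from 14000 nM to 90000 nM.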

Compound 3, half-maximal inhibitory concentration: 77900 nM
For compound 3 the middle estimate is 2.2-fold (0.34 log units) below the measured one; the measured number falls inside the stated range.
By their numbers in this assay, from the lowest: compound 1; then compounds 2 and 3 (each within the scatter of the next).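

In this assay the swap of 4-chlorophenyl for 3-methoxyphenyl gives a 1.0-fold higher number from compound 2 to compound 3 (0.02 log units; within the scatter) and so leaves the number unchanged within the scatter, even though the entering group is larger and adds a hydrogen-bond acceptor. Keeping the 3-substitution pattern and changing only the substituent, methoxy in place of chloro, gives a 2.6-fold higher number from compound 1 to compound 3 (0.41 log units; beyond the scatter) at this position ortho to a cyano group, a comparison the earlier compounds could not offer. Among these three, compound 1 alone stands apart with the lowest number, so the shared 3-substitution pattern does not by itself bring compound 3 to that level. No measured evidence here explains these results. A 4-methoxyphenyl group would show whether methoxy matches chlorine at the other ring position, while an aminophenyl or carboxyphenyl group at this place remains untested in the compounds shown.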